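Acetoxy in Place of Chloro: an Expected Step

The source may hold more compounds than are shown below. What is called first, only, known or untested is meant among the compounds shown, and "the series" means these compounds.

compound 1, `CC(C)(C)c1cc(NC(=O)Nc2ccc(-c3cc4ccccc4s3)cc2)no1`: > 900 nM
compound 2, `CC(C)(C)c1cc(NC(=O)Nc2ccc(-c3cn4ccc(Cl)cc4n3)cc2)no1`: 5.91 nM

In a functional assay on MV4-11 cells (Homo sapiens) for cytotoxicity, read by MTT assay, with a stated time of 72 h (on this read-out higher numbers stand for weaker inhibition and lower numbers for stronger inhibition), compound 1 gives a value that is a limit of the assay, > 900 nM. In this assay, among the measured compounds shown here, compound 2 gives 5.91 nM, the only number among the values shown; the other entry is the limit of > 900 nM in this assay, at which 1 of the 2 values shown sits. Compound 3, `CC(=O)Oc1ccn2cc(-c3ccc(NC(=O)Nc4cc(C(C)(C)C)on4)cc3)nc2c1`, differs from compound 2 by acetoxy in place of chloro on an aromatic carbon. For the measured compounds named here, no step between measured compounds is known here. Compound 3 is expected to give 15 nM in this assay, between 4 nM and 60 nM. The expected step of a 2.5-fold higher number from compound 2 to compound 3 (0.40 log units; beyond the scatter) would be a modest weakening, near the edge of the scatter.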

Compound 3, half-maximal inhibitory concentration: 29.4 nM
Compound 3: middle estimate off by 2.0-fold (0.29 log units), on the low side, and the stated range covers the measured number.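

Chloro is not required at this position opposite the ring nitrogen, since the much larger acetoxy is accepted at a modest cost in this assay: a 5.0-fold higher number from compound 2 to compound 3 (0.70 log units; beyond the scatter). Compound 3 still gives a measured number, 29.4 nM, so this site takes a group with a carbonyl and still reads clearly in this assay. Nothing measured here accounts for the step.

The compounds shown leave open how a hydroxy group, a methoxy group or an amine would read at this position. They also leave open whether acetoxy would cost the same on another carbon of that ring.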